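This account rests on a few compounds, and the source may have more. Where it says the series, first, only, none or still open, it means among the compounds named here.

Measured in an ADME assay on MDCK cells (Canis lupus familiaris) for cytotoxicity, read by MTT assay, with a stated time of 24 h; a higher number here means that more compound is tolerated, a lower number that less compound is tolerated:
- compound 1 `N#CCCN(Cc1ccco1)S(=O)(=O)c1ccc(Cl)cc1`: > 205000 nM (a limit)
- compound 2 `Cc1ccc(S(=O)(=O)N(CCC#N)Cc2ccco2)cc1`: > 219000 nM (a limit)

In this assay, compound 2 gives > 219000 nM, which is a limit and not a number. Compound 1 also stands at a limit, so neither compound offers a number to work from.

Compound 3 `Cc1cccc(S(=O)(=O)N(CCC#N)Cc2ccco2)c1` differs from compound 2 as follows: 3-methylphenyl in place of 4-methylphenyl on a sulfonyl sulfur. This places 3-methylphenyl in place of 4-methylphenyl on a sulfonyl sulfur, with the same atoms joined differently.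

Within the data shown here, the only measured step is a step that the two limits leave unreadable from compound 1 to compound 2. It is a different change, methyl in place of chloro on an aromatic carbon, and gives no size to carry over. In this assay, no step beyond the scatter is expected, and no direction can be assigned. The expected result is a step that the limit leaves unreadable from compound 2 to compound 3. Another limit is the likely report. For compound 3, the estimate is 250000 nM, with an expected range of 130000 nM to 480000 nM.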

Compound 3, half-maximal cytotoxic concentration: > 219000 nM
Compound 3: no number, only a limit; the forecaster's own chance of this, stated with the estimate: 85%; the middle value is on the limit's open side.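

In this assay compound 3 gives > 219000 nM, a limit and not a number. No step can be read among compound 1, compound 2 and compound 3, as all three stand at limits. Left open is whether 4-chlorophenyl, 4-methylphenyl and 3-methylphenyl on the sulfonyl sulfur differ at all in this assay.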